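The compounds below may be only part of what the source reports. "The series", "measured", "known", "first", "only" and "open" are said of these compounds alone.

Three compounds share one core and differ only in a substituent on one of their aromatic rings. In a functional assay, tested at 200 ug/mL (on this read-out lower numbers stand for a stronger effect and higher numbers for a weaker effect at the one concentration tested), compound 1, `CCOC(=O)C1=C(C)N(c2ccccc2)C=CC1c1ccccc1`, gives -29.3%. Compound 2, `CCOC(=O)C1=C(C)N(c2ccc(Cl)cc2)C=CC1c1ccccc1`, gives -31.1%, and compound 3, `CCOC(=O)C1=C(C)N(c2ccc(Br)cc2)C=CC1c1ccccc1`, gives -35.7%. The step of a number 1.8 percentage points lower from compound 1 to compound 2 (within the scatter) and the step of a number 6.4 percentage points lower from compound 1 to compound 3 (within the scatter) both fall inside the usual scatter, so compound 1 stands among three numbers that cannot be told apart.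

Compound 4, `CCOC(=O)C1=C(C)N(c2ccccc2)C=CC1c1ccccc1[N+](=O)[O-]`, is built from compound 1 by the change (nitro in place of hydrogen on an aromatic carbon). Within the data shown here, this change sits on a different ring from the ones altered in compounds 2 and 3, so no measured step bears on it directly. Among the measured compounds shown here, the only guidance is that two changes on the shared core left this read-out unmoved beyond the scatter. Compound 4 is therefore expected to show a number 0.7 percentage points lower from compound 1 to compound 4 (within the scatter), no step beyond the scatter. The estimate for compound 4 is -30%, within a range from -46% to -14%.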

Compound 4, a percentage reported as activity, at one concentration (the size of the read-out at that concentration, not a potency): -26.9%
Compound 4: the middle estimate sits 3.1 percentage points below what was measured; the range from low to high includes it.
By their numbers in this assay, from the lowest: compounds 3, 2, 1 and 4 (each within the scatter of the next).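

Going from phenyl to 2-nitrophenyl brings a second ring of the shared core into the comparison, and in this assay this change gives a number 2.4 percentage points higher from compound 1 to compound 4 (within the scatter). A group of three heavy atoms, placed on an aromatic carbon ortho to a large group, therefore produces no readable step, and the same holds for the chloro and bromo changes on the other ring. Nothing available here bears on why this read-out stays put.

As far as these compounds go, whether an amine or a carboxylic acid at this same position would produce a step beyond the scatter remains open. Also open, from the compounds shown here alone, is whether nitro on a different carbon of this ring would behave as it does here, and a single concentration says nothing about potency.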